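A few compounds are considered here, and "the series" means these few. Any claim that something is new, unique, unknown or untested is made for them only; others in the source may bear on it.

For the measured compounds named here, in a functional assay on RAW264.7 cells (Mus musculus) for inhibition, read by Griess assay, with a stated time of 24 h (a lower number here means a stronger inhibitor, a higher number a weaker inhibitor), compound 1 (`C=CCc1ccc(O)c(-c2cc(CCC)on2)c1`) gives 61000 nM and compound 2 (`C=CCc1ccc(O)c(-c2cc(CO)on2)c1`) gives 36000 nM, so compound 1 stands within the scatter of its only measured neighbour. Compound 3 (`CCCc1cc(-c2cc(Br)ccc2O)no1`) differs from compound 1 as follows: bromo in place of allyl on an aromatic carbon. Going by the values given here, the only measured step, a 1.7-fold lower number from compound 1 to compound 2 (0.23 log units; within the scatter), lies elsewhere on the core and leaves the allyl untouched. The data therefore give no direction for this change, and no step beyond the scatter is expected in this assay. The estimated value for compound 3 is 40000 nM, with an expected range of 12000 nM to 100000 nM. This estimate means a 1.5-fold lower number from compound 1 to compound 3 (0.18 log units; within the scatter).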

Compound 3, half-maximal inhibitory concentration: 63000 nM
Beside the measured number, compound 3's estimate is 1.6-fold (0.20 log units) below it; low and high end bracket the measured number.
By their numbers in this assay, from the lowest: compounds 2, 1 and 3 (each within the scatter of the next).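

For the compounds shown here, at the aromatic carbon para to the hydroxy group, bromo in place of allyl gives a 1.0-fold higher number from compound 1 to compound 3 (0.01 log units; within the scatter), the first reading at this position, which the earlier step left untouched. The allyl can thus give way to bromo without moving the number beyond the scatter in this assay. Nothing measured here bears on why this is so. As far as these compounds go, whether an amine or a carboxylic acid on this carbon would shift the number beyond the scatter stays open, and so does the effect of a longer chain there.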